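From Furan to Thiophene on the Shared Core

The source may report more compounds than this note shows. Statements on the series, on what has been measured and on what is new or still open speak of the compounds shown alone.

Of the compounds shown here, three sharing one core have been measured in an assay on membranes from CHO cells for displacement of a labelled ligand from adenosine receptor A1 (Homo sapiens), read by scintillation counting, with a stated time of 60 min, tested at 1 uM; a higher number here means more inhibition at the concentration tested (going by the name of the read-out), a lower number less inhibition. Compound 1 `COC(=O)C1=C(C)NC(=O)NC1c1ccoc1` gives 8%, the lowest of the three numbers. Compound 2 `CCCOC(=O)C1=C(C)NC(=O)NC1c1ccoc1` gives 50%, and compound 3 `CC1=C(C(=O)OCc2ccccc2)C(c2ccoc2)NC(=O)N1` gives 41%. Both differ from compound 1 only in the ester: a number 42 percentage points higher from compound 1 to compound 2 (beyond the scatter) with ethyl in place of hydrogen on a saturated chain carbon bound to an oxygen next to a carbonyl group, and a number 33 percentage points higher from compound 1 to compound 3 (beyond the scatter) with phenyl in place of hydrogen on that same saturated chain carbon. Between these two, a number 9 percentage points lower from compound 2 to compound 3 (within the scatter). Compound 1 therefore gives the lowest number of the three measured compounds in this assay.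

Compound 4 `COC(=O)C1=C(C)NC(=O)NC1c1cccs1` keeps the methoxycarbonyl group of compound 1 and changes the ring instead: thiophen-2-yl in place of furan-3-yl on a saturated ring carbon. Among the measured compounds shown here, none of the measured steps touches this ring, since all three concern the ester substituent, so the change has no direct precedent among the measured compounds. As an expectation only, the step of a number 7 percentage points higher from compound 1 to compound 4 (within the scatter) is taken to be none beyond the scatter. Compound 4 is accordingly estimated at 15%, with a range from 0% to 40% to reflect the absence of any measured guidance.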

Compound 4, a percentage reported as inhibition, at one concentration (the size of the read-out at that concentration, not a potency): 6%
The estimate for compound 4 lay 9 percentage points above the measured number, within the range that was stated.
By their numbers in this assay, from the lowest: compounds 4 and 1 (each within the scatter of the next); then compounds 3 and 2 (each within the scatter of the next).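

Within this assay, thiophen-2-yl in place of furan-3-yl on the saturated ring carbon, next to the ring nitrogen, gives a number 2 percentage points lower from compound 1 to compound 4 (within the scatter), so with the methoxycarbonyl group kept, this exchange of one five-membered aromatic ring for another leaves the number level. The earlier compounds shown here changed only the ester and gave large steps, such as a number 42 percentage points higher from compound 1 to compound 2 (beyond the scatter), so they said nothing about this ring carbon; this first change there, by contrast, does not lift compound 4 out of the range of compound 1. No measurement at hand offers an explanation for this outcome.

The compounds shown leave open whether thiophen-2-yl would also stay level with furan-3-yl when paired with the larger esters of compound 2 and compound 3, where the numbers are higher and a change might read differently. They also leave open how a simple phenyl group or a pyridin-3-yl group would fare on this same saturated ring carbon, and whether the outcome seen here extends beyond this one pair of rings.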